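This account rests on a few compounds, and the source may have more. Where it says the series, first, only, none or still open, it means among the compounds named here.

Measured compounds:
compound 1 `CC(=O)OC[C@H]1O[C@@H](n2cc(CN3C(=O)/C(=C\c4ccccc4)c4ccccc43)nn2)[C@H](OC(C)=O)[C@@H](OC(C)=O)[C@@H]1OC(C)=O` with 22800 nM in an ADME assay on NIH3T3 cells (Homo sapiens) for cytotoxicity, read by sulforhodamine B assay, with a stated time of 48 h; on this read-out lower numbers stand for stronger inhibition and higher numbers for weaker inhibition
compound 2 `CC(=O)OC[C@H]1O[C@@H](n2cc(CN3C(=O)/C(=C\c4ccc(C)cc4)c4ccccc43)nn2)[C@H](OC(C)=O)[C@@H](OC(C)=O)[C@@H]1OC(C)=O` with 9000 nM in this assay

Among the measured compounds shown here, compound 2 gives the lowest of the two numbers in this assay; the only step known to it is a 2.5-fold lower number from compound 1 to compound 2 (0.40 log units; beyond the scatter). Compound 3 `COc1ccc(/C=C2\C(=O)N(Cc3cn([C@@H]4O[C@H](COC(C)=O)[C@@H](OC(C)=O)[C@H](OC(C)=O)[C@H]4OC(C)=O)nn3)c3ccccc32)cc1OC` differs from compound 2 by 3,4-dimethoxyphenyl in place of 4-methylphenyl on a double-bonded chain carbon bound to a double-bonded ring carbon. For the measured compounds named here, no measured step covers an exchange of this kind; the single known step, a 2.5-fold lower number from compound 1 to compound 2 (0.40 log units; beyond the scatter), concerns another change on the same ring and is modest. The expected step is therefore small, no change at the digits printed from compound 2 to compound 3 (within the scatter), with no direction beyond the scatter. Compound 3 is estimated at 9000 nM in this assay, within 3000 nM to 27000 nM.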

Compound 3, half-maximal inhibitory concentration: > 100000 nM
Compound 3 ended at the assay's limit; the forecaster's own chance of this, stated with the estimate: 10%; middle value at least 11-fold (1.04 log units) from the limit.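

At the place on a double-bonded chain carbon bound to a double-bonded ring carbon, the aryl group can move the number in either direction. In this assay, 3,4-dimethoxyphenyl gives an at least 11-fold higher number from compound 2 to compound 3 (1.04 log units; beyond the scatter) and an at least 4.3-fold higher number from compound 1 to compound 3 (0.64 log units; beyond the scatter), against the lower number seen with 4-methylphenyl. Compound 3 stands at a limit of the assay, so its true size of step stays unknown: the limit of > 100000 nM in this assay, at which 1 of the 3 values shown sits.

On these data alone, whether a single methoxy group would be enough for this rise stays open. So does the outcome with an amine or a chlorine on this aromatic ring.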